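The source may hold more compounds than are shown below. What is called first, only, known or untested is meant among the compounds shown, and "the series" means these compounds.

Working notes on the series. Compound 3 `CC(=O)c1ccc(NC(=O)C2CCCN2S(=O)(=O)c2ccc([N+](=O)[O-])cc2)cc1` gives 25.6% in a functional assay for inhibition, read by spectrophotometry, with a stated time of 20 min, tested at 5 mg/mL (a lower number here means a weaker effect, a higher number a stronger effect of the compound at the concentration tested), the lowest of the three numbers seen so far. Compound 1 `CCC(C)C(C(=O)Nc1ccc(C(C)=O)cc1)N(C(=O)c1ccccc1)S(=O)(=O)c1ccc(C)cc1` gives 47.3%, and compound 2 `CC(=O)c1ccc(NC(=O)C2CC(O)CN2S(=O)(=O)c2ccc([N+](=O)[O-])cc2)cc1` gives 70.7%. Among the compounds with values here, the one single-point step in the set runs a number 45.1 percentage points lower from compound 2 to compound 3 (beyond the scatter).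

Compound 4 `CC(=O)c1ccc(NC(=O)C2CCCN2S(=O)(=O)c2ccccc2)cc1` has not yet been measured. It differs from compound 3 by hydrogen in place of nitro on an aromatic carbon. No measured step touches an aromatic substituent: the only step shown concerns a hydroxy on a saturated ring carbon, so it carries no direct weight for this change. Compound 1 lacks the nitro group but also differs from compound 3 in other places. Compound 1 gives 47.3%, while compound 3 gives 25.6%. With more than one difference between them, those two values only show that a compound without nitro can sit higher, not what removing nitro alone does.

Within the data shown here, with no bearing step, the expectation for compound 4 is a step of a number 2.6 percentage points lower from compound 3 to compound 4 (within the scatter), that is, nothing beyond the scatter. Compound 4 is therefore estimated at 23%, within a range of 5% to 45%, the breadth reflecting the absence of any guiding step.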

Compound 4, a percentage reported as inhibition, at one concentration (the size of the read-out at that concentration, not a potency): 35.7%
Beside the measured number, compound 4's estimate is 12.7 percentage points below it; low and high end bracket the measured number.
By their numbers in this assay, from the lowest: compound 3; then compound 4; then compound 1; then compound 2.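

In this assay, within the data shown here, the change from 4-nitrophenyl to phenyl, on an aromatic carbon para to a large group, gives a number 10.1 percentage points higher from compound 3 to compound 4 (beyond the scatter), the first step that isolates a change on this aromatic ring. It shows that the nitro group is not needed for the read-out on this core: with hydrogen in its place the number rises beyond the scatter, and the step is modest, whereas the hydroxy step, a number 45.1 percentage points lower from compound 2 to compound 3 (beyond the scatter), is large. No measurement in hand bears on the reason for this rise, so the step stands only as an observation.

The compounds shown leave open whether the same change would give a step of the same direction and size on the hydroxy-bearing core of compound 2, since this step is read only on the core without hydroxy. They also leave open how other groups at this position would compare with hydrogen and nitro, such as an amine, a methoxy group or a carboxylic acid, so a single pair cannot yet be extended into a trend for this position.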